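Adding a Second Chloro to Compound 1: an Expectation

The source may hold more compounds than are shown below. What is called first, only, known or untested is meant among the compounds shown, and "the series" means these compounds.

The measured compounds:
compound 1 `CCc1nc2c(C)cc(C)nc2n1Cc1ccc(OC(C(=O)O)c2ccccc2)c(Cl)c1`, giving 720 nM in an assay on Midbrain with Type-2 angiotensin II receptor (Rattus norvegicus) as the target; a lower number here means a stronger inhibitor, a higher number a weaker inhibitor
compound 2 `CCc1nc2c(C)cc(C)nc2n1Cc1ccc(OC(C(=O)O)c2ccccc2)c(C)c1`, giving 940 nM in this assay
compound 3 `CCc1nc2c(C)cc(C)nc2n1Cc1ccc(OC(C(=O)O)c2ccccc2)c(C(=O)c2ccccc2)c1`, giving 60 nM in this assay

Among these three, compound 1 stands second highest. Its nearest neighbour is compound 2, the step being a 1.3-fold higher number from compound 1 to compound 2 (0.12 log units; within the scatter); its furthest is compound 3, with a 12-fold lower number from compound 1 to compound 3 (1.08 log units; beyond the scatter).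

Compound 4 `CCc1nc2c(C)cc(C)nc2n1Cc1cc(Cl)c(OC(C(=O)O)c2ccccc2)c(Cl)c1` differs from compound 1 in one place: chloro in place of hydrogen on an aromatic carbon. Among the compounds with values here, no measured pair tries this change, so the guidance is indirect. Swapping the existing small group for another small group, a 1.3-fold higher number from compound 1 to compound 2 (0.12 log units; within the scatter), stayed within the scatter, whereas the benzoyl swaps a 12-fold lower number from compound 1 to compound 3 (1.08 log units; beyond the scatter) and a 16-fold lower number from compound 2 to compound 3 (1.19 log units; beyond the scatter) were large. Adding one more small group is expected to behave more like the former than the latter, with any shift small and of uncertain direction. Compound 4 is therefore expected near 550 nM, within 180 nM to 1700 nM. The step this estimate implies, a 1.3-fold lower number from compound 1 to compound 4 (0.12 log units; within the scatter), is expected to stay within the scatter.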

Compound 4, half-maximal inhibitory concentration: 9000 nM
For compound 4 the middle estimate is 16-fold (1.21 log units) below the measured one; the whole stated range lies below it.
By their numbers in this assay, from the lowest: compound 3; then compounds 1 and 2 (each within the scatter of the next); then compound 4.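

In this assay, a chloro on the aromatic carbon ortho to a carboxy(phenyl)methoxy group, where compound 1 carries hydrogen, gives a 13-fold higher number from compound 1 to compound 4 (1.10 log units; beyond the scatter) and so shows that this carbon is far from silent. A single added chlorine moves the number about as far as the benzoyl swap, a 12-fold lower number from compound 1 to compound 3 (1.08 log units; beyond the scatter), does, but in the opposite direction, whereas the exchange of one small group for another, a 1.3-fold higher number from compound 1 to compound 2 (0.12 log units; within the scatter), on the other side of the same ring stayed within the scatter. Nothing shown here accounts for this step.

Going by these compounds, whether the rise belongs to chloro itself or to any group on this carbon stays open, as a fluoro, methyl or methoxy group there would show. Also open, on these data alone, is whether a second substituent here would cost as much alongside the benzoyl group of compound 3.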